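Inverting both stereocentres of compound 2

The compounds below may be only part of what the source reports. "The series", "measured", "known", "first", "only" and "open" are said of these compounds alone.

In an ADME assay on S9 fraction from liver (Homo sapiens) for metabolic stability, with a stated time of 1 h (on this read-out higher numbers stand for a more stable compound and lower numbers for a less stable compound), compound 2 (`N#Cc1cnc(NCc2cnccc2C(F)(F)F)cc1NC[C@H]1CC[C@@H](O)CC1`) stands lowest of the two measured compounds at 41% and compound 1 (`N#Cc1cnc(NCc2cnccc2C(F)(F)F)cc1NC[C@H]1C[C@H](O)C1`) stands at 93% on the same read-out. Compound 3 (`N#Cc1cnc(NCc2cnccc2C(F)(F)F)cc1NC[C@H]1CC[C@H](O)CC1`) keeps the atoms and bonds of compound 2 (the two compounds have the same atoms and bonds and differ only in configuration as drawn: 2 of 2 stereo elements differ (all stereocentres are inverted: mirror images); a stereocentre at a saturated ring carbon is drawn s in compound 2 and r in compound 3; a stereocentre at a saturated ring carbon is drawn s in compound 2 and r in compound 3) and differs only in configuration as drawn.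

Going by the values given here, one measured step bears on this (a number 52 percentage points lower from compound 1 to compound 2 (beyond the scatter)) for 4-hydroxycyclohexyl in place of 3-hydroxycyclobutyl. Among the compounds with values here, it is large and beyond the scatter, but it exchanges the ring, and no measured pair isolates a change of configuration. The expectation therefore stays close to compound 2 at 41% with a wide margin, and no step beyond the scatter is expected. The expected step is a number 5 percentage points higher from compound 2 to compound 3 (within the scatter) and no direction is firmly implied. For compound 3 the estimated value is 46% (expected range from 24% to 72%).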

Compound 3, percent of the compound remaining: 32%
Compound 3: the middle estimate sits 14 percentage points above what was measured; measured number inside the range.
By their numbers in this assay, from the lowest: compounds 3 and 2 (each within the scatter of the next); then compound 1.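

In this assay inverting both stereocentres of the 4-hydroxycyclohexyl group gives a number 9 percentage points lower from compound 2 to compound 3 (within the scatter), so the two drawn configurations are not separated on this read-out. Going by these compounds alone, this pair gives the first reading of configuration alone at this position, which the earlier pair, with its change of ring, could not give: the fact that compounds 2 and 3 differ only in the configuration as drawn. The ring exchange is now seen with both cyclohexyl configurations, with a number 61 percentage points lower from compound 1 to compound 3 (beyond the scatter) alongside the earlier a number 52 percentage points lower from compound 1 to compound 2 (beyond the scatter), so the large step for 4-hydroxycyclohexyl in place of 3-hydroxycyclobutyl holds for either form.

Still open, on these data alone, is whether configuration matters on the 3-hydroxycyclobutyl ring, where only compound 1 stands. Also open, as far as these compounds go, is whether compound 1 would keep its stability with a methoxy group or an amine in place of the hydroxyl on that ring.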